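This account rests on a few compounds, and the source may have more. Where it says the series, first, only, none or still open, it means among the compounds named here.

Measured compounds:
Compound 1, `CC(=O)N(O)C(C)c1ccc2oc(-c3ccccc3)cc2c1`: 490 nM
Compound 2, `CCCCCCCCCCc1cc2cc(C(C)N(O)C(C)=O)ccc2o1`: 410 nM

In an assay on RBL cells for inhibition of Polyunsaturated fatty acid 5-lipoxygenase (Rattus norvegicus) (on this read-out higher numbers stand for weaker inhibition and lower numbers for stronger inhibition), compound 1 gives 490 nM, and compound 2 gives 410 nM in this assay; the two numbers lie within the usual scatter of each other, so neither can be set above or below the other. Compound 3, `CC(c1ccc2oc(-c3ccccc3)cc2c1)N(O)C(=O)c1ccccc1`, has not been measured in this assay. It differs from compound 1 in one place: phenyl in place of methyl on a carbonyl carbon. For the measured compounds named here, no measured pair in this set shows what such a change does, so the expected size of the step rests only on the scatter of the assay and on the numbers for compound 1 and compound 2. The step from compound 1 to compound 3 in this assay is estimated as a 1.4-fold higher number from compound 1 to compound 3 (0.15 log units; within the scatter), a modest move toward weaker inhibition. For compound 3 in this assay the estimate is 700 nM, with a range from 250 nM to 2000 nM.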

Compound 3, half-maximal inhibitory concentration: 4830 nM
Beside the measured number, compound 3's estimate is 6.9-fold (0.84 log units) below it, outside the stated range (above it).
By their numbers in this assay, from the lowest: compounds 2 and 1 (each within the scatter of the next); then compound 3.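

Putting phenyl in place of methyl on the carbonyl carbon, the change from acetyl to benzoyl, gives in this assay a 9.9-fold higher number from compound 1 to compound 3 (0.99 log units; beyond the scatter), so on the core of compound 1 this position does not accept the larger group without a loss of inhibition. Compound 1 and compound 2 both carry the acetyl, so neither of them could show how this position responds to a change. The compounds shown offer no measurement that accounts for this loss.

As far as these compounds go, it remains open how an ethyl, a longer chain or an amine on the same carbonyl carbon would read in this assay, and so whether the phenyl ring itself matters or any group larger than methyl would do the same. From the compounds shown here alone, it is also open whether the change from acetyl to benzoyl would give a step of similar size on compound 2.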